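The source may hold more compounds than are shown below. What is called first, only, known or untested is meant among the compounds shown, and "the series" means these compounds.

Measured compounds:
- compound 1 `Nc1cc(N)c2nc(-c3ccccc3)c(NCc3ccc(Cl)c(Cl)c3)nc2c1`: 55000 nM
- compound 2 `CCOC(=O)[C@H](CCC(=O)O)NC(=O)c1ccc(Oc2nc3cc(N)cc(N)c3nc2-c2ccccc2)cc1`: 60300 nM

Both numbers come from a functional assay on NCI-H23 cells (Homo sapiens) for inhibition, read by sulforhodamine B assay, with a stated time of 48 h; on this read-out lower numbers stand for higher toxicity in this test and higher numbers for lower toxicity in this test. In this assay compound 1 gives 55000 nM and compound 2 gives 60300 nM; the two values sit within the scatter of each other, so neither can be set apart from the other on this read-out. Compound 1 is simply the reference point for the next step.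

Compound 3 `COc1ccc(CNc2nc3cc(N)cc(N)c3nc2-c2ccccc2)cc1` has not yet been tested in this assay. It differs from compound 1 in one place: 4-methoxyphenyl in place of 3,4-dichlorophenyl on a saturated chain carbon bound to a nitrogen on an aromatic ring. No measured pair in this series shows the effect of this exchange, so no shown step can be used as a guide. With both measured analogues close together and weakly active, the expectation is for a step from compound 1 to compound 3 of a 1.3-fold higher number from compound 1 to compound 3 (0.10 log units; within the scatter), not clearly beyond the scatter, if anything toward a higher number. Compound 3 is thus estimated at 70000 nM, in the range 30000 nM to 160000 nM.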

Compound 3, concentration lethal to 50% of the cells: 70800 nM
Compound 3: middle estimate off by 1.0-fold (0.00 log units), on the low side; measured number inside the range.
By their numbers in this assay, from the lowest: compounds 1, 2 and 3 (each within the scatter of the next).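

In this assay the exchange of 3,4-dichlorophenyl for 4-methoxyphenyl on a saturated chain carbon bound to a nitrogen on an aromatic ring gives a 1.3-fold higher number from compound 1 to compound 3 (0.11 log units; within the scatter) and this step lies within the scatter. Going by these compounds alone, this is the first one-place step, and it shows that this read-out does not separate these two groups at this position, even though the two chlorine atoms give way to a methoxy group that adds a hydrogen-bond acceptor. No measured information on the compounds accounts for this result. A single exchange cannot show whether any group at this position would move the number beyond the scatter. An amine or a carboxylic acid in place of 4-methoxyphenyl, or a longer chain in place of 3,4-dichlorobenzyl, remains an open test of that question.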